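A few compounds are considered here, and "the series" means these few. Any claim that something is new, unique, unknown or untested is made for them only; others in the source may bear on it.

Measured in an ADME assay on TZM cells (Homo sapiens) for cytotoxicity, with a stated time of 1 days; on this read-out lower numbers stand for higher toxicity in this test and higher numbers for lower toxicity in this test:
- Compound 1 `Cc1cc(CCC#N)cc(C)c1Oc1cc(Nc2ccc(C#N)cc2)c(N)cc1C(=O)N(C)C`: 38200 nM
- Compound 2 `Cc1cc(CCC#N)cc(C)c1Oc1cc(Nc2ccc(C#N)cc2)c(N)cc1CN(C)C`: 23800 nM
- Compound 3 `Cc1cc(CCC#N)cc(C)c1Oc1cc(Nc2ccc(C#N)cc2)c(N)cc1COC(=O)C1CC1`: 42200 nM

Compound 3, at 42200 nM, cannot be ranked against the other two compounds, as its values lie within the scatter of both. The unmeasured compound 4 `Cc1cc(CCC#N)cc(C)c1Oc1ccc(N)c(Nc2ccc(C#N)cc2)c1` differs from it by one change: hydrogen in place of ((cyclopropylcarbonyl)oxy)methyl on an aromatic carbon.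

For the measured compounds named here, three measured steps bear on this change, all of them exchanges of the group on that same aromatic carbon. They are a 1.1-fold higher number from compound 1 to compound 3 (0.04 log units; within the scatter), a 1.8-fold higher number from compound 2 to compound 3 (0.25 log units; within the scatter) and a 1.6-fold lower number from compound 1 to compound 2 (0.21 log units; within the scatter). None of them leaves the scatter, whether the group is dimethylcarbamoyl, (dimethylamino)methyl or ((cyclopropylcarbonyl)oxy)methyl. None of them, however, puts hydrogen at that place, so the data reach this change only indirectly and the range must stay wide. On this evidence, no step beyond the scatter is expected in this assay, and no direction can be firmly assigned. The expected step is a 1.3-fold lower number from compound 3 to compound 4 (0.12 log units; within the scatter). For compound 4 the estimated value is 32000 nM, with an expected range from 14000 nM to 75000 nM.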

Compound 4, half-maximal cytotoxic concentration: > 200000 nM
Compound 4: a limit, no number (the forecaster's own chance of this, stated with the estimate: 10%); at least 6.2-fold (0.79 log units) between middle value and limit.
By their numbers in this assay, from the lowest: compounds 2, 1 and 3 (each within the scatter of the next). At a limit, above all of these: compound 4.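

Compound 4 stands at a limit of the assay, not at a number: the limit of > 200000 nM in this assay, at which 1 of the 4 values shown sits. In this assay, dimethylcarbamoyl, (dimethylamino)methyl and ((cyclopropylcarbonyl)oxy)methyl on this aromatic carbon stayed within the scatter of one another, whereas hydrogen at the same place gives steps beyond the scatter: an at least 4.7-fold higher number from compound 3 to compound 4 (0.67 log units; beyond the scatter), an at least 8.4-fold higher number from compound 2 to compound 4 (0.92 log units; beyond the scatter) and an at least 5.2-fold higher number from compound 1 to compound 4 (0.71 log units; beyond the scatter). At this position, then, what separates the compounds in this read-out is whether one of these three groups or hydrogen is present, not which of the three it is, and hydrogen lies on the side of lower toxicity in this test.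

The compounds shown leave open how far the true value of compound 4 lies past its limit, so each of these steps gives only a lower bound on its size. They also leave open whether a single methyl, a hydroxymethyl or a carboxylic acid on this aromatic carbon would fall with hydrogen or with the three groups already compared.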